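Replacing the 2-methoxyphenyl group of compound 2

This account rests on a few compounds, and the source may have more. Where it says the series, first, only, none or still open, it means among the compounds named here.

Measured in a functional assay on MCF7 cells (Homo sapiens) for cytotoxicity, read by CellTiter-Glo, with a stated time of 5 days; on this read-out higher numbers stand for weaker inhibition and lower numbers for stronger inhibition:
- compound 1 `CC/C(=C(/c1ccc(/C=C/C(=O)O)cc1)c1ccc2[nH]ncc2c1)c1cccc(C#N)c1`: 100 nM
- compound 2 `CC/C(=C(/c1ccc(/C=C/C(=O)O)cc1)c1ccc2[nH]ncc2c1)c1ccccc1OC`: 25 nM

Compound 2 holds the lower of the two numbers in this assay, at 25 nM. Among the measured compounds shown here, its only measured neighbour is compound 1, and the step between them is a 4.0-fold lower number from compound 1 to compound 2 (0.60 log units; beyond the scatter).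

Next in line is compound 3 `CC/C(=C(/c1ccc(/C=C/C(=O)O)cc1)c1ccc2[nH]ncc2c1)c1ccc(C#N)cc1Cl`, with 2-chloro-4-cyanophenyl in place of 2-methoxyphenyl on a double-bonded chain carbon bound to a double-bonded chain carbon and a saturated chain carbon.

For the measured compounds named here, only one measured step bears on this change, the modest 4.0-fold lower number from compound 1 to compound 2 (0.60 log units; beyond the scatter), made at the same place. It is a partial guide. The entering group shares its cyano with the 3-cyanophenyl of compound 1 at 100 nM, and it shares a substituent at the 2 position with the 2-methoxyphenyl of compound 2 at 25 nM. Two compounds cannot separate these features, so an expectation between the two values seems reasonable, and no step beyond the scatter is expected.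

The estimated step is a 1.6-fold higher number from compound 2 to compound 3 (0.20 log units; within the scatter). For compound 3 the expected value is 40 nM, with an estimated range of 10 nM to 150 nM.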

Compound 3, half-maximal inhibitory concentration: 4 nM
Compound 3: the middle estimate sits 10-fold (1.00 log units) above what was measured; the measured number lies below the stated range.
By their numbers in this assay, from the lowest: compound 3; then compound 2; then compound 1.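

In this assay, the place on the double-bonded chain carbon bound to a double-bonded chain carbon and a saturated chain carbon still has room below the value of compound 2: 2-chloro-4-cyanophenyl gives a 6.3-fold lower number from compound 2 to compound 3 (0.80 log units; beyond the scatter), and against the other nitrile-bearing compound it gives a 25-fold lower number from compound 1 to compound 3 (1.40 log units; beyond the scatter). A nitrile on this ring therefore does not go with the higher number by itself, as compound 1 alone might have suggested: nitrile-bearing rings now stand at both ends of the order, with compound 1 highest and compound 3 lowest. No measured property of these groups is at hand to account for either step.

Compound 3 differs from compound 1 and from compound 2 in more than one feature of the ring, so the shares of chlorine and nitrile stay unresolved, and a phenyl carrying chlorine alone or nitrile alone at this place would be needed to divide them. Also open, going by these compounds, is whether the same order holds with an amide in place of the carboxylic acid on the shared core.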